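One Exchange on Two Cores in a Whole-Animal Assay

A few compounds are considered here, and "the series" means these few. Any claim that something is new, unique, unknown or untested is made for them only; others in the source may bear on it.

Compound 1 `O=C1NCCN1CC#CCn1ccnc1` and compound 2 `CN(C)CC#CCN1CCNC1=O` share one core and differ in a single place: dimethylamino in place of 1H-imidazol-1-yl on a saturated chain carbon bound to a triple-bonded carbon. In a functional assay on the whole organism for antagonist activity, with Mus musculus as the target (a higher number here means that more compound is needed for the effect, a lower number that less compound is needed), compound 1 gives > 100 mg/kg, which is a limit of the assay and not a number. In this assay compound 2 gives > 100 mg/kg, likewise a limit. The step that the two limits leave unreadable from compound 1 to compound 2 is therefore not readable; both values sit at the limit of > 100 mg/kg in this assay, at which 3 of the 3 values shown sit.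

Compound 3 `Cn1ccn(CC#CCn2ccnc2)c1=O` carries a different core; the difference between the two cores is not broken down here. In this assay compound 3 gives > 100 mg/kg, again a limit of the assay. Compound 4 `CN(C)CC#CCn1ccn(C)c1=O` has not yet been measured in this assay. It differs from compound 3 by dimethylamino in place of 1H-imidazol-1-yl on a saturated chain carbon bound to a triple-bonded carbon, the same change that separates compound 1 from compound 2, made at the same place; it occurs twice among the compounds shown.

What to expect for compound 4 rests on thin ground. The change has been made once before, and the step it made cannot be read, because the same change from compound 1 to compound 2 gave only a step that the two limits leave unreadable from compound 1 to compound 2, with both ends at the limit of > 100 mg/kg in this assay, at which 3 of the 3 values shown sit. Compound 3 itself stands at a limit. From compound 3 to compound 4 an estimated step that the limit leaves unreadable from compound 3 to compound 4 is expected. Compound 4 is expected to give 200 mg/kg, with a likely range from 50 mg/kg to 1000 mg/kg, and most probably the assay will again report only a limit.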

Compound 4, dose for half-maximal effect: > 100 mg/kg
Compound 4: no number, only a limit; the forecaster's own chance of this, stated with the estimate: 85%; the middle value is on the limit's open side.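

In this assay compound 4 gives > 100 mg/kg, which is a limit of the assay and not a number. The step from compound 3 to compound 4 therefore cannot be read, and all compounds shown rest at the same value: the limit of > 100 mg/kg in this assay, at which 4 of the 4 values shown sit.

The compounds shown leave open whether dimethylamino in place of 1H-imidazol-1-yl changes the dose needed in this assay on either core, and whether the two cores differ at all.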